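Removing a Trifluoromethyl Group from Compound 2

A few compounds are considered here, and "the series" means these few. Any claim that something is new, unique, unknown or untested is made for them only; others in the source may bear on it.

Measured in a functional assay on MDA-MB-231 cells (Homo sapiens) for antiproliferative activity, read by sulforhodamine B assay, with a stated time of 72 h; on this read-out higher numbers stand for weaker inhibition and lower numbers for stronger inhibition:
Compound 1 `COc1ccc2nc(Cl)c(/C=C\c3ccc(C(F)(F)F)cc3)cc2c1`: 22800 nM
Compound 2 `COc1ccc2nc(Cl)c(/C=C\c3ccc(C(F)(F)F)cc3C(F)(F)F)cc2c1`: > 50000 nM (a limit of the assay)

Compound 2 stands at a limit and has no number on this assay. The next compound, compound 3 `COc1ccc2nc(Cl)c(/C=C\c3ccccc3C(F)(F)F)cc2c1`, comes from compound 2 through one change: hydrogen in place of trifluoromethyl on an aromatic carbon. This places hydrogen where a trifluoromethyl group stood, on an aromatic carbon para to a large group, and the other trifluoromethyl group stays in place.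

For the measured compounds named here, only one measured step bears on this, an at least 2.1-fold higher number from compound 1 to compound 2 (0.34 log units; beyond the scatter). It is the same kind of exchange, running in the opposite direction and on another aromatic carbon, so it is an indirect guide. Read backwards, it suggests a lower number for compound 3, meaning stronger inhibition, though probably not far from compound 1 with 22800 nM. The starting point is only a limit, so the size of the change remains loosely defined. The expected change is an at least 1.6-fold lower number from compound 2 to compound 3 (0.22 log units; that floor lies within the scatter). For compound 3 the estimated value is 30000 nM, with an expected range from 12000 nM to 50000 nM.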

Compound 3, half-maximal inhibitory concentration: 2770 nM
For compound 3 the middle estimate is 11-fold (1.03 log units) above the measured one, outside the stated range (below it).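

In this assay, the exchange on this aromatic carbon, para to a large group, gives an at least 18-fold lower number from compound 2 to compound 3 (1.25 log units; beyond the scatter), so the trifluoromethyl group at this place separates a compound with a measured number from one without. The earlier step, an at least 2.1-fold higher number from compound 1 to compound 2 (0.34 log units; beyond the scatter), concerned another aromatic carbon and could only hint at what this position would do; the new step shows directly that hydrogen here, with the other trifluoromethyl group left in place, goes with much stronger inhibition in this assay. Compound 2 stands at a limit of the assay, so the new step is a floor and its full size cannot be read: the limit of > 50000 nM in this assay, at which 1 of the 3 values shown sits.

The compounds shown leave open whether hydrogen is the best choice on this carbon, since only trifluoromethyl and hydrogen appear there, and how a fluorine atom, a methoxy group or an amine would compare. They also leave open what the remaining trifluoromethyl group, which stands meta to this place, contributes to the number of compound 3, as every compound shown carries at least one trifluoromethyl group on this ring.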